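The source may hold more compounds than are shown below. What is called first, only, known or untested is meant among the compounds shown, and "the series" means these compounds.

Values measured in an ADME assay on microsomes from liver (Mus musculus) for metabolic stability, using NADPH, with a stated time of 10 min (on this read-out lower numbers stand for a less stable compound and higher numbers for a more stable compound), are these:

Compound 1 `CCCCc1nc(=O)c(S(=O)(=O)c2ccc(-c3ccc(F)cc3)cc2)c(O)n1-c1c(OC)cccc1OC` gives 47%
Compound 2 `CCCCc1[nH]c(=O)c(S(=O)(=O)c2ccc(-c3ccc(F)cc3)cc2)c(O)c1-c1c(OC)cccc1OC` gives "not determined" (no result reported)
Compound 3 `CCCCc1[nH]c(=O)c(S(=O)(=O)c2ccc(-c3cccnc3OC)cc2)c(O)c1-c1c(OC)cccc1OC` gives 24%

Compound 1 holds the higher of the two numbers, and compound 3 stands lower by a gap beyond the usual scatter. Compound 2 has no number. Compound 4 (`CCCCc1nc(=O)c(S(=O)(=O)c2ccc(C3CC3)cc2)c(O)n1-c1c(OC)cccc1OC`) differs from compound 1 in one place only (cyclopropyl in place of 4-fluorophenyl on an aromatic carbon), with cyclopropyl in place of 4-fluorophenyl on an aromatic carbon. For the measured compounds named here, no measured pair shows this change alone, so the data offer no direct guide. The estimated step of a number 3 percentage points higher from compound 1 to compound 4 (within the scatter) is expected to stay within the usual scatter, with no clear direction. For compound 4 the estimated value in this assay is 50% with an expected range from 28% to 72% across repeated measurements.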

Compound 4, percent of the compound remaining: 93%
Beside the measured number, compound 4's estimate is 43 percentage points below it; measured number above the stated range.
By their numbers in this assay, from the lowest: compound 3; then compound 1; then compound 4.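

In this assay, cyclopropyl in place of 4-fluorophenyl on an aromatic carbon para to a large group gives a number 46 percentage points higher from compound 1 to compound 4 (beyond the scatter). This is the first change in one place among these compounds, and it shows that this position strongly affects the read-out. No measurement given here accounts for the step. The compounds shown leave open whether the size of the group or the aromatic ring matters more. They also leave open how a morpholine, an amine or a longer chain would read at this position.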